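The compounds below may be only part of what the source reports. "The series", "measured", "known", "first", "only" and "open" are said of these compounds alone.

Measured so far:
compound 1, `Cc1nc2cc(OC[C@H](O)CN3CCN(Cc4nnc(-c5ccc(C(C)(C)C)cc5)o4)CC3)ccc2s1`: 1100 nM
compound 2, `Cc1nc2cc(OC[C@H](O)CN3CCN(Cc4nnc(-c5ccc(Cl)cc5)o4)CC3)ccc2s1`: 8500 nM

In a functional assay on mitochondria from heart for inhibition of peroxisomal acyl-coenzyme A oxidase 1 (Rattus norvegicus) (a higher number here means a weaker inhibitor, a lower number a stronger inhibitor), compound 2 has the highest number of the two measured, its nearest neighbour being compound 1 at a 7.7-fold higher number from compound 1 to compound 2 (0.89 log units; beyond the scatter). The step to compound 3, `Cc1nc2cc(OC[C@H](O)CN3CCN(Cc4nnc(-c5ccc(C(F)(F)F)cc5)o4)CC3)ccc2s1`, is trifluoromethyl in place of chloro on an aromatic carbon. Among the measured compounds shown here, the only measured step that bears on it is the one from compound 1 to compound 2, a 7.7-fold higher number from compound 1 to compound 2 (0.89 log units; beyond the scatter), which runs between the two groups that bracket the incoming one. A partial reversal of that step is therefore expected: compound 3 is estimated at 3000 nM, range 1200 nM to 9000 nM, a step of a 2.8-fold lower number from compound 2 to compound 3 (0.45 log units; beyond the scatter) in this assay.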

Compound 3, half-maximal inhibitory concentration: 4800 nM
Beside the measured number, compound 3's estimate is 1.6-fold (0.20 log units) below it; the measured number falls inside the stated range.
By their numbers in this assay, from the lowest: compound 1; then compounds 3 and 2 (each within the scatter of the next).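

In this assay, the change from 4-chlorophenyl to 4-(trifluoromethyl)phenyl gives a 1.8-fold lower number from compound 2 to compound 3 (0.25 log units; within the scatter), so chloro and trifluoromethyl are not separated at this position. Tert-butyl does stand apart from trifluoromethyl, with a 4.4-fold higher number from compound 1 to compound 3 (0.64 log units; beyond the scatter), which leaves tert-butyl alone at the low end of the three groups. Nothing available accounts for this gap. Still open, going by these compounds, is whether a carboxylic acid, an amine or a methoxy group at this place would fall with tert-butyl or with the other two, and whether a longer alkyl chain would lower the number further.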